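This account rests on a few compounds, and the source may have more. Where it says the series, first, only, none or still open, it means among the compounds named here.

Measured in a functional assay on the whole organism with Scenedesmus acutus as the target, with a stated time of 20 h; a lower number here means a stronger inhibitor, a higher number a weaker inhibitor:
- compound 1 `COC(=O)c1cc(N2C(=O)C3=C(CCCC3)C2=O)ccc1Cl`: 1620 nM
- compound 2 `COC(=O)c1cc(N2C(=O)C3=C(CCCC3)C2=O)c(F)cc1Cl`: 170 nM
- compound 3 `CC(C)OC(=O)c1cc(N2C(=O)C3=C(CCCC3)C2=O)c(F)cc1Cl`: 89.1 nM

Compound 1 has the highest number of the three, so it is the weakest inhibitor in this small set. Compound 4 `CCCCOC(=O)c1cc(N2C(=O)C3=C(CCCC3)C2=O)ccc1Cl` is made from it by one change: propyl in place of hydrogen on a saturated chain carbon bound to an oxygen next to a carbonyl group. Put more simply, methyl becomes butyl, or methoxycarbonyl becomes butoxycarbonyl.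

Two measured steps are available, but they do not bear equally on this change. The larger, a 9.5-fold lower number from compound 1 to compound 2 (0.98 log units; beyond the scatter), comes from fluoro in place of hydrogen on an aromatic carbon, which is a different kind of change and offers little guidance. The closer precedent is a 1.9-fold lower number from compound 2 to compound 3 (0.28 log units; within the scatter), where isopropyl replaces methyl on an oxygen next to a carbonyl group. Among the measured compounds shown here, that step lies within the scatter and was measured with the fluoro present, and no measured compound carries a butyl group. Only a small step toward a lower number in this assay is therefore expected, and it may not exceed the scatter.

The estimated change is a 1.6-fold lower number from compound 1 to compound 4 (0.21 log units; within the scatter). For compound 4 the expected value is 1000 nM, with an estimated range from 350 nM to 2600 nM.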

Compound 4, half-maximal inhibitory concentration: 7760 nM
Compound 4: middle estimate off by 7.8-fold (0.89 log units), on the low side; measured number above the stated range.
By their numbers in this assay, from the lowest: compounds 3 and 2 (each within the scatter of the next); then compound 1; then compound 4.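

In this assay, going from methoxycarbonyl to butoxycarbonyl gives a 4.8-fold higher number from compound 1 to compound 4 (0.68 log units; beyond the scatter), which means a weaker inhibitor and shows that this change on the oxygen can matter by more than the scatter. Among the compounds shown here, the only earlier change at this place, a 1.9-fold lower number from compound 2 to compound 3 (0.28 log units; within the scatter), stayed within the scatter, and it involved isopropyl rather than butyl and had the fluoro present. Nothing available explains why butyl gives the weaker result.

From the compounds shown here alone, it remains open whether the same change from methyl to butyl would give a similar step with the fluoro of compound 2 present. Going by these compounds, how an ethyl chain, a propyl chain, a longer chain or a free carboxylic acid in place of methoxycarbonyl would behave also remains unknown.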